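A few compounds are considered here, and "the series" means these few. Any claim that something is new, unique, unknown or untested is made for them only; others in the source may bear on it.

Measured so far in a functional assay on A-375 cells (Homo sapiens) for cytotoxicity, read by MTT assay, with a stated time of 72 h, tested at 10 uM; a lower number here means less inhibition of growth, a higher number more inhibition of growth at the concentration tested:
compound 1 `Cc1ccnc(/C(N)=N/NC(=S)N2CCOCC2)c1` gives 86%
compound 2 `Cc1cccc(/C(N)=N/NC(=S)N2CCSCC2)n1` gives 62.6%
compound 3 `Cc1ccnc(/C(N)=N/NC(=S)N2CCSCC2)c1` gives 74.5%

Compound 2 stands lowest of these three numbers; compound 3 lies nearest to it and compound 1 furthest, and both gaps are beyond the scatter. Compound 4 `Cc1cccc(/C(N)=N/NC(=S)N2CCCCC2)n1` has not been measured yet. It differs from compound 2 in one place: piperidin-1-yl in place of thiomorpholin-4-yl on a thiocarbonyl carbon. Among the measured compounds shown here, the only measured step that comes close is a number 11.5 percentage points lower from compound 1 to compound 3 (beyond the scatter), where the ring on the thiocarbonyl carbon was exchanged as well, though between morpholin-4-yl and thiomorpholin-4-yl rather than for piperidin-1-yl. For the measured compounds named here, that step was modest, so a change of similar size is the most this exchange can be expected to bring, and no measured step tells in which direction the exchange for piperidin-1-yl moves the number. Compound 4 is therefore expected to give about 60% in this assay, within 45% to 76%. The expected step of a number 2.6 percentage points lower from compound 2 to compound 4 (within the scatter) thus stays within the scatter.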

Compound 4, percent growth inhibition at one concentration: 76.4%
Estimate against measurement, compound 4: 16.4 percentage points below, outside the stated range (above it).
By their numbers in this assay, from the lowest: compound 2; then compounds 3, 4 and 1 (each within the scatter of the next, the first and the last beyond it).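

In this assay, the group on the thiocarbonyl carbon matters on the core of compound 2 as well, not only on the core of compound 1: with a number 13.8 percentage points higher from compound 2 to compound 4 (beyond the scatter), a six-membered ring with carbon where thiomorpholin-4-yl has its sulfur gives a clear rise. Together with a number 11.5 percentage points lower from compound 1 to compound 3 (beyond the scatter), this means that in both measured pairs the thiomorpholin-4-yl compound is the lower one, although the two pairs have different cores and different partner rings. Nothing available explains why the exchange raises the number.

Still open, on these data alone, is how piperazin-1-yl, with a second ring nitrogen, or an open-chain dimethylamino group would behave on the thiocarbonyl carbon. The effect of piperidin-1-yl on the core of compound 1 is open too, as is whether morpholin-4-yl would also score high on the core of compound 2.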